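A few compounds are considered here, and "the series" means these few. Any claim that something is new, unique, unknown or untested is made for them only; others in the source may bear on it.

In a functional assay on A549 cells (Homo sapiens) for inhibition, read by MTT assay, with a stated time of 48 h (a higher number here means a weaker inhibitor, a lower number a stronger inhibitor), compound 1 (`CCC(C)NC(=O)/C=C/c1c(/C=C/c2ccc(OC)cc2)cc(OC)cc1OC`) gives 3950 nM and compound 2 (`COc1ccc(/C=C/c2cc(OC)cc(OC)c2/C=C/C(=O)N2CCCCC2)cc1`) gives 10600 nM while compound 3 (`CCCCCCNC(=O)/C=C/c1c(/C=C/c2ccc(OC)cc2)cc(OC)cc1OC`) gives 6230 nM and so lies within the scatter of both. Compound 4 (`COc1ccc(/C=C/c2cc(OC)cc(OC)c2/C=C/C(=O)N2CCCC(C)C2)cc1`) carries 3-methylpiperidin-1-yl in place of hexylamino on a carbonyl carbon. Its closest measured relative is compound 2, and the step of a 1.7-fold lower number from compound 2 to compound 3 (0.23 log units; within the scatter) stays within the scatter, as does the step of a 1.6-fold higher number from compound 1 to compound 3 (0.20 log units; within the scatter) between the sec-butyl and hexyl amides. Within the data shown here, only the step of a 2.7-fold higher number from compound 1 to compound 2 (0.43 log units; beyond the scatter) goes beyond it, and modestly. Among the measured compounds shown here, no measured compound shows what the added methyl does. Resting on compound 2 at 10600 nM as the nearest guide, a small expected step (a 1.4-fold higher number from compound 3 to compound 4 (0.16 log units; within the scatter)) is no more than the scatter. For compound 4 the estimated value is 9000 nM (range 4500 nM to 18000 nM).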

Compound 4, half-maximal inhibitory concentration: 5820 nM
Compound 4: the middle estimate sits 1.5-fold (0.19 log units) above what was measured; the measured number falls inside the stated range.
By their numbers in this assay, from the lowest: compounds 1, 4, 3 and 2 (each within the scatter of the next, the first and the last beyond it).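

In this assay the methyl on a saturated ring carbon gives a 1.8-fold lower number from compound 2 to compound 4 (0.26 log units; within the scatter) and so stays within the scatter. Placing 3-methylpiperidin-1-yl on the carbonyl carbon gives a 1.1-fold lower number from compound 3 to compound 4 (0.03 log units; within the scatter) against hexylamino and a 1.5-fold higher number from compound 1 to compound 4 (0.17 log units; within the scatter) against (sec-butyl)amino, so compound 4 lies within the scatter of both amides that keep the amide hydrogen, although a 2.7-fold higher number from compound 1 to compound 2 (0.43 log units; beyond the scatter) goes beyond it. No available evidence explains these steps. From the compounds shown here alone, whether a hydroxyl or a carboxylic acid on that ring carbon would move the number beyond the scatter stays open, as does the effect of morpholin-4-yl on the carbonyl carbon.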